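Replacing the Arylamino Group on the Amide Carbonyl

This account rests on a few compounds, and the source may have more. Where it says the series, first, only, none or still open, it means among the compounds named here.

Compound 1 `O=C(Nc1cccc(-n2cc(-c3ccncc3)c(-c3ccc(Cl)c(O)c3)n2)c1)Nc1cccc(C(F)(F)F)c1`: > 32500 nM
Compound 2 `COc1cc(-c2nn(-c3cccc(NC(=O)Nc4cccc(C(F)(F)F)c4)c3)cc2-c2ccncc2)ccc1Cl`: > 50000 nM

Both values in a functional assay on SK-OV-3 cells (Homo sapiens) for inhibition, read by sulforhodamine B assay, with a stated time of 48 h (a higher number here means that more compound is tolerated, a lower number that less compound is tolerated), are limits of the assay rather than numbers. Compound 1 sits at the limit > 32500 nM. Compound 2 sits at the limit > 50000 nM. Among the compounds with values here, the single measured step, a step that the two limits leave unreadable from compound 1 to compound 2, is methyl in place of hydrogen on an oxygen on an aromatic ring, and its size cannot be read; compound 2 therefore stands only at a limit, as the evidence the limit of > 50000 nM in this assay, at which 1 of the 2 values shown sits, and the limit of > 32500 nM in this assay, at which 1 of the 2 values shown sits, shows.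

Compound 3 `COc1cc(-c2nn(-c3cccc(NC(=O)c4ccccc4)c3)cc2-c2ccncc2)ccc1Cl` differs from compound 2 by phenyl in place of (3-(trifluoromethyl)phenyl)amino on a carbonyl carbon. Within the data shown here, no measured step bears on this change, so no direction can be drawn from the data. Compound 3 is expected in this assay at 50000 nM, within 15000 nM to 150000 nM. The step of a number no higher from compound 2 to compound 3 (the limit leaves the size open) is estimated as no more than scatter.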

Compound 3, concentration lethal to 50% of the cells: > 100000 nM
Compound 3 ended at the assay's limit; the forecaster's own chance of this, stated with the estimate: 75%; middle value at least 2.0-fold (0.30 log units) from the limit.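

Within the data shown here, compound 2 and compound 3 both stand at limits of this assay, so the step between them cannot be read and no new step emerges. The compounds shown leave open what numerical value any of them would reach in this read-out, and whether the change on the carbonyl carbon shifts it.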